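Shifting one fluorine in a rapidly cleared compound

This account rests on a few compounds, and the source may have more. Where it says the series, first, only, none or still open, it means among the compounds named here.

Compound 1 `OC(c1ncccc1F)C1(c2ccc(Cl)c(Cl)c2)CCC1`: 3000 mL/min/kg
Compound 2 `O[C@H](c1ccccn1)[C@]1(c2ccc(C(F)(F)F)cc2)C[C@@H](O)C1`: 50 mL/min/kg

In an ADME assay on liver for metabolic stability, with Liver microsome (Rattus norvegicus) as the target, read by LC-MS, using microsomes, with a stated time of 5 h (a higher number here means faster removal of the compound, a lower number slower removal), compound 1 stands at 3000 mL/min/kg, the higher of the two numbers. Compound 2 gives 50 mL/min/kg, and the gap between them lies beyond the usual scatter, so compound 1 is the one removed faster.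

Compound 3 `OC(c1ccc(F)cn1)C1(c2ccc(Cl)c(Cl)c2)CCC1` has not been measured yet. It has the same atoms as compound 1, joined differently: 5-fluoropyridin-2-yl in place of 3-fluoropyridin-2-yl on a saturated chain carbon bound to an oxygen on a saturated carbon and a saturated ring carbon. In words, 5-fluoropyridin-2-yl stands in place of 3-fluoropyridin-2-yl on a saturated chain carbon bound to an oxygen on a saturated carbon and a saturated ring carbon.

Going by the values given here, no two measured compounds differ in just one place, so the data do not show what a change of this kind does. The best anchor is therefore compound 1 at 3000 mL/min/kg, and in this assay no change beyond the scatter is expected, with no firm direction. The estimate amounts to an expected step of a 1.2-fold lower number from compound 1 to compound 3 (0.08 log units; within the scatter). For compound 3 the estimated clearance is 2500 mL/min/kg, with an expected range of 1000 mL/min/kg to 6000 mL/min/kg.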

Compound 3, clearance: 3170 mL/min/kg
Compound 3: the middle estimate sits 1.3-fold (0.10 log units) below what was measured, within the range that was stated.
By their numbers in this assay, from the lowest: compound 2; then compounds 1 and 3 (each within the scatter of the next).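

Moving the fluorine from 3-fluoropyridin-2-yl to 5-fluoropyridin-2-yl gives a 1.1-fold higher number from compound 1 to compound 3 (0.02 log units; within the scatter) in this assay. Going by these compounds alone, this pair offers the first direct reading of a single change: at this place, on a saturated chain carbon bound to an oxygen on a saturated carbon and a saturated ring carbon, the two fluorine placements cannot be told apart by their clearance. Nothing available explains why the two compounds cannot be separated in this measurement.

The compounds shown leave open whether a different group on this pyridine ring, such as an amine or a carboxylic acid in place of the fluorine, would give a number clearly apart from those of compound 1 and compound 3 in this assay. Going by these compounds, compound 2 differs from both of them in more than one place, so it remains unknown which of those differences, taken alone, would shift the clearance of the shared core.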